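The compounds below may be only part of what the source reports. "The series", "measured", "known", "first", "only" and "open" are said of these compounds alone.

Measured so far:
- compound 1, `Cc1ccccc1S(=O)(=O)NC(=O)c1ccc(Nc2nc(NC3(c4ccc(Cl)cc4)CC3)nc(OCC(F)(F)F)n2)cc1`: 100%
- compound 2, `O=C(NS(=O)(=O)C1CC1)c1ccc(Nc2nc(NC3(c4ccc(Cl)cc4)CC3)nc(OCC(F)(F)F)n2)cc1`: 85%
- compound 3, `CN(C)S(=O)(=O)NC(=O)c1ccc(Nc2nc(NC3(c4ccc(Cl)cc4)CC3)nc(OCC(F)(F)F)n2)cc1`: 76%

In an ADME assay on microsomes from liver (Rattus norvegicus) for metabolic stability, with a stated time of 10 min (on this read-out lower numbers stand for a less stable compound and higher numbers for a more stable compound), compound 3 stands lowest of the three numbers. Its nearest neighbour is compound 2, and the step of a number 9 percentage points lower from compound 2 to compound 3 (within the scatter) is within the scatter; the furthest is compound 1, with the step of a number 24 percentage points lower from compound 1 to compound 3 (beyond the scatter) beyond the scatter.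

Compound 4, `O=C(NS(=O)(=O)CCNCc1ccccc1)c1ccc(Nc2nc(NC3(c4ccc(Cl)cc4)CC3)nc(OCC(F)(F)F)n2)cc1`, differs from compound 3 in one place: 2-(benzylamino)ethyl in place of dimethylamino on a sulfonyl sulfur.

All three measured steps also exchange the group on the sulfonyl sulfur. Both a number 15 percentage points lower from compound 1 to compound 2 (beyond the scatter) and a number 24 percentage points lower from compound 1 to compound 3 (beyond the scatter) are modest lowerings, while a number 9 percentage points lower from compound 2 to compound 3 (within the scatter) is within the scatter. For the measured compounds named here, no measured step covers a chain of this kind with a ring in it, so there is nothing to anchor the direction firmly. Given that every exchange at this position so far has moved the number downward or left it unchanged, a further modest lowering, or none beyond the scatter, is expected in this assay, with wide uncertainty.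

For compound 4 the estimated value is 65%, within 35% to 95%, corresponding to an expected step of a number 11 percentage points lower from compound 3 to compound 4 (beyond the scatter).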

Compound 4, percent of the compound remaining: 100%
The estimate for compound 4 lay 35 percentage points below the measured number, outside the stated range (above it).
By their numbers in this assay, from the lowest: compounds 3 and 2 (each within the scatter of the next); then compounds 1 and 4 (each within the scatter of the next).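

In this assay, exchanges on the sulfonyl sulfur no longer run only downward or stay within the scatter: with 2-(benzylamino)ethyl in place of the smaller groups, the series shows a number 24 percentage points higher from compound 3 to compound 4 (beyond the scatter) and a number 15 percentage points higher from compound 2 to compound 4 (beyond the scatter). Against 2-methylphenyl, the same chain gives no change at the digits printed from compound 1 to compound 4 (within the scatter), so a group with a ring on a flexible chain and a ring placed directly on the sulfur read alike here. Nothing available accounts for these steps.

From the compounds shown here alone, it remains open whether the benzene ring or the chain nitrogen of 2-(benzylamino)ethyl goes with the higher number; a plain 2-aminoethyl group and an all-carbon 3-phenylpropyl chain would separate the two. Going by these compounds, it is also open how far compound 1 and compound 4 would stay alike at a longer incubation time in this assay.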